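The source may report more compounds than this note shows. Statements on the series, on what has been measured and on what is new or still open speak of the compounds shown alone.

In a functional assay on the whole organism (Abdomen, strain Swiss) for inhibition, with Mus musculus as the target, with stated times of 30 min, 10 min and 5 min, at a dose of 10 mg/kg by the oral route (a lower number here means a weaker effect, a higher number a stronger effect of the compound at the dose given), compound 1, `CC(=O)c1c(C)nn(CCCN2CCN(c3ccc(C)cc3)CC2)c(=O)c1N`, gives 19%. Compound 2, `CCC(=O)c1c(C)nn(CCCN2CCN(c3ccc(C)cc3)CC2)c(=O)c1N`, differs by methyl in place of hydrogen on a saturated chain carbon bound to a carbonyl carbon and gives 9% in this assay, a change of a number 10 percentage points lower from compound 1 to compound 2 (within the scatter). Compound 3, `C/C=C/c1c(C)nn(CCCN2CCN(c3ccc(C)cc3)CC2)c(=O)c1N`, differs from compound 1 by prop-1-en-1-yl in place of acetyl on an aromatic carbon. In this assay compound 3 gives 0%. The step is a number 19 percentage points lower from compound 1 to compound 3 (beyond the scatter), while against compound 2 it is a number 9 percentage points lower from compound 2 to compound 3 (within the scatter).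

Compound 4, `CC/C=C/c1c(C)nn(CCCN2CCN(c3ccc(C)cc3)CC2)c(=O)c1N`, has not been measured. It differs from compound 3 by methyl in place of hydrogen on a saturated chain carbon bound to a double-bonded chain carbon. Going by the values given here, this is the same kind of change as the one from compound 1 to compound 2, though the place differs: there the added methyl sits on a saturated chain carbon bound to a carbonyl carbon, here on a saturated chain carbon bound to a double-bonded chain carbon, and the two cores differ by prop-1-en-1-yl in place of acetyl on an aromatic carbon.

Beside a number 10 percentage points lower from compound 1 to compound 2 (within the scatter), the step from compound 3 to compound 4 is expected to be about a number 2 percentage points higher from compound 3 to compound 4 (within the scatter), resting on that earlier step and on compound 3 already giving 0%, so little room remains below. Compound 4 is therefore estimated at 2%, likely between 0% and 15%.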

Compound 4, a percentage reported as inhibition, in the whole organism at one dose (the size of the read-out at that dose, not a potency): 5%
Compound 4: the middle estimate sits 3 percentage points below what was measured, within the range that was stated.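

The methyl does not carry over as one fixed shift from the core of compound 1 to the core of compound 3 in this assay: the same change on two cores in this assay, a number 10 percentage points lower (within the scatter) from compound 1 to compound 2 and a number 5 percentage points higher (within the scatter) from compound 3 to compound 4, 15 percentage points apart, beyond the scatter of two such steps. Yet the new step, a number 5 percentage points higher from compound 3 to compound 4 (within the scatter), and the earlier one each stay small on their own, so this does not show that the methyl truly lowers the effect on one core and raises it on the other. Replacing the carbonyl side chain with but-1-en-1-yl gives a number 14 percentage points lower from compound 1 to compound 4 (beyond the scatter), but a number 4 percentage points lower from compound 2 to compound 4 (within the scatter).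

Two pairs cannot show how the methyl would behave on further cores. The compounds shown also leave open how a longer chain, or an amine, on that aromatic carbon would read in this assay.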